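Swapping ethylcarbamoyl for methoxy on a weak chloro compound

The source may report more compounds than this note shows. Statements on the series, on what has been measured and on what is new or still open speak of the compounds shown alone.

Compound 1 `CCNC(=O)c1ccc(CN(C)C(=O)c2cc(Cl)c(O)cc2O)cc1` value 21700 nM
Compound 2 `CCNC(=O)c1ccc(CN(C)C(=O)c2cc(C(C)C)c(O)cc2O)cc1` value 460 nM

Among the measured compounds shown here, in a functional assay on NCI-H1975 cells (Homo sapiens) for antiproliferative activity, with a stated time of 72 h (a higher number here means a weaker inhibitor of growth, a lower number a stronger inhibitor of growth), compound 1 has the higher of the two numbers, and the one measured step leads down from it (a 47-fold lower number from compound 1 to compound 2 (1.67 log units; beyond the scatter)). That step puts isopropyl in place of chloro on an aromatic carbon, which is a different change from the one followed here. Compound 3 `COc1ccc(CN(C)C(=O)c2cc(Cl)c(O)cc2O)cc1` keeps the chloro of compound 1 and differs elsewhere (methoxy in place of ethylcarbamoyl on an aromatic carbon), with methoxy in place of ethylcarbamoyl on an aromatic carbon, para to a large group. For the measured compounds named here, no measured pair shows what a change at this place does. The measured step therefore sets no direction, though it shows that one exchange moved compound 1 a long way. Only a modest change is expected, with a wide margin (a 1.1-fold lower number from compound 1 to compound 3 (0.04 log units; within the scatter)). Compound 3 is estimated at 20000 nM with a range from 6000 nM to 60000 nM in this expectation.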

Compound 3, concentration for 50% growth inhibition: 16700 nM
For compound 3 the middle estimate is 1.2-fold (0.08 log units) above the measured one, within the range that was stated.
By their numbers in this assay, from the lowest: compound 2; then compounds 3 and 1 (each within the scatter of the next).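

In this assay, among the compounds shown here, methoxy in place of ethylcarbamoyl on an aromatic carbon, para to a large group, gives the first reading at this position (a 1.3-fold lower number from compound 1 to compound 3 (0.11 log units; within the scatter)), so compound 1 and compound 3 cannot be told apart. With the chloro kept, the larger ethylcarbamoyl group and its hydrogen-bond donor can therefore give way to methoxy with no difference beyond the scatter, in contrast to the large step at the other place (a 47-fold lower number from compound 1 to compound 2 (1.67 log units; beyond the scatter)). Nothing in the available data gives a reason for this result.

Going by these compounds, whether this exchange would read the same with isopropyl in place of chloro stays open, since that would need a weak chloro background to be left behind. Also open, on these data alone, is what a primary amine or a carboxylic acid at this place would do.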